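Swapping the aryl group on the amide nitrogen

This account rests on a few compounds, and the source may have more. Where it says the series, first, only, none or still open, it means among the compounds named here.

In a functional assay on T47D cells (Homo sapiens) for inhibition, read by CCK-8 assay, with a stated time of 72 h, tested at 10 uM (on this read-out lower numbers stand for less inhibition of growth and higher numbers for more inhibition of growth at the one concentration tested), compound 1 `CN(C)C(=O)c1cc2cnc(Nc3ccc(NC(=O)C4(C(=O)Nc5cccc(F)c5)CC4)cc3)nc2n1C1CCCC1` gives -0.4% and compound 2 `CN(C)C(=O)c1cc2cnc(Nc3ccc(NC(=O)C4(C(=O)Nc5ccc(Br)cc5)CC4)cc3)nc2n1C1CCCC1` gives 94.3%, so compound 2 stands highest of the two, beyond the scatter. Compound 3 `CN(C)C(=O)c1cc2cnc(Nc3ccc(NC(=O)C4(C(=O)Nc5cccc(C(F)(F)F)c5)CC4)cc3)nc2n1C1CCCC1` has not yet been measured. It carries 3-(trifluoromethyl)phenyl in place of 4-bromophenyl on an amide-type nitrogen.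

Among the measured compounds shown here, one measured step bears on this change: the large a number 94.7 percentage points higher from compound 1 to compound 2 (beyond the scatter), which lies beyond the scatter and involves the same amide-type nitrogen. Compound 3 gives up the 4-bromophenyl of compound 2, and the name of its 3-(trifluoromethyl)phenyl gives the same position as that of the 3-fluorophenyl of compound 1. A single step cannot show how far a different group at that place would follow compound 1, so the expectation stays wide. A fall beyond the scatter is expected, of a size smaller than the measured step, and it is estimated as a number 59.3 percentage points lower from compound 2 to compound 3 (beyond the scatter). For compound 3 the estimated value is 35%, with an expected range of 0% to 85%.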

Compound 3, percent growth inhibition at one concentration: 92.7%
The estimate for compound 3 lay 57.7 percentage points below the measured number, outside the stated range (above it).
By their numbers in this assay, from the lowest: compound 1; then compounds 3 and 2 (each within the scatter of the next).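

In this assay, 3-(trifluoromethyl)phenyl in place of 4-bromophenyl on the amide-type nitrogen comes with a number 1.6 percentage points lower from compound 2 to compound 3 (within the scatter), so among the compounds shown, 4-bromophenyl is not the only aryl group at this place that gives a high number. Trifluoromethyl in place of fluoro on the aromatic carbon comes with a number 93.1 percentage points higher from compound 1 to compound 3 (beyond the scatter), so the shared "3-" in the names 3-fluorophenyl and 3-(trifluoromethyl)phenyl does not decide the outcome, and the low number of compound 1 cannot be tied to that ring position alone. No measurement in hand accounts for either step.

Among the compounds shown here, with only three aryl groups compared, it remains open how other groups on this ring would read, such as a methoxy group or an amine, and whether a pyridine ring in place of the phenyl ring would keep the growth inhibition. Because the read-out uses a single concentration, it also leaves open whether compound 2 and compound 3 would still read alike across a range of concentrations.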